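The compounds below may be only part of what the source reports. "The series", "measured", "known", "first", "only" and "open" are said of these compounds alone.

Measured compounds:
compound 1, `CCN(CC)Cc1ccc(C)c(Nc2nc3ccccc3n2Cc2ccc(C#N)cc2)c1O`, > 50000 nM
compound 2, `CCN(CC)Cc1ccc(Nc2nc3ccccc3n2Cc2ccc(C#N)cc2)cc1O`, 39000 nM
compound 3, `CCN(CC)Cc1ccc(C)c(Nc2nc3ccccc3n2Cc2ccc(F)cc2)c1O`, > 50000 nM

The three compounds were tested in an ADME assay on CHO cells (Cricetulus griseus) for inhibition, read by MTT assay; on this read-out lower numbers stand for stronger inhibition and higher numbers for weaker inhibition. Compound 1 gives only a limit of the assay in this assay, > 50000 nM, and not a number. Compound 3 likewise gives only a limit there, > 50000 nM. Within the data shown here, compound 2 is the sole compound with a number, giving 39000 nM in this assay.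

Compound 3 differs from compound 1 by one change, (fluoro in place of cyano on an aromatic carbon). The step that the two limits leave unreadable from compound 1 to compound 3 cannot be read because both compounds sit at the limit of > 50000 nM in this assay, at which 2 of the 3 values shown sit. How the core of compound 2 differs from that of compound 1 is not broken down here.

Compound 4, `CCN(CC)Cc1ccc(Nc2nc3ccccc3n2Cc2ccc(F)cc2)cc1O`, has not yet been measured in this assay. It differs from compound 2 by fluoro in place of cyano on an aromatic carbon, the same change as that from compound 1 to compound 3. Since that earlier step is unreadable, the expectation for compound 4 rests on compound 2 alone, whose value is 39000 nM. Compound 4 is therefore expected to show a step of about a 1.2-fold higher number from compound 2 to compound 4 (0.06 log units; within the scatter), within the usual scatter, and there is a fair chance that it, too, returns only a limit. The estimate for compound 4 in this assay is 45000 nM, between 20000 nM and 100000 nM.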

Compound 4, half-maximal inhibitory concentration: 45800 nM
Compound 4: the middle estimate sits 1.0-fold (0.01 log units) below what was measured; measured number inside the range.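

In this assay, putting fluoro in place of cyano on the core of compound 2 gives a 1.2-fold higher number from compound 2 to compound 4 (0.07 log units; within the scatter), so on this read-out compound 2 and compound 4 cannot be told apart, and the 4-cyanobenzyl and 4-fluorobenzyl groups read alike on this core. Among these compounds, the same change on the core of compound 1 cannot be read, because compound 1 and compound 3 each give only a limit of the assay and not a number: the limit of > 50000 nM in this assay, at which 2 of the 4 values shown sit. The series therefore offers one readable step on one core, which shows that the change is tolerated without a readable shift on the core of compound 2 but does not show that it behaves the same way on the core of compound 1, as no two steps can be set side by side.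

Open is how a carboxylic acid or an amine on that same aromatic carbon would read in this assay, as cyano and fluoro are the only groups shown there. Also open, as far as these compounds go, is whether a group such as methoxy at that place would bring any compound on the core of compound 1 to a number rather than a limit.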